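From Morpholine to Thiomorpholine: An Expected Cytotoxicity Step

The compounds below may be only part of what the source reports. "The series", "measured", "known", "first", "only" and "open" are said of these compounds alone.

The measured compounds in a functional assay on A-375 cells (Homo sapiens) for cytotoxicity, read by MTT assay, with a stated time of 72 h, tested at 3 uM (on this read-out lower numbers stand for less inhibition of growth and higher numbers for more inhibition of growth at the one concentration tested), are:
compound 1 `Cc1cccc(/C(N)=N/NC(=S)N2CCN(c3ccccn3)CC2)n1` gives 61.8%
compound 2 `N/C(=N\NC(=S)N1CCOCC1)c1ccccn1` gives 19.3%
compound 3 `N/C(=N\NC(=S)N1CCCC1)c1ccc(F)cn1` gives 81.8%

Among these three, compound 2 stands lowest in this assay. Its nearest neighbour is compound 1, whose number lies higher by a margin beyond the usual scatter, and the furthest is compound 3, higher still by a margin that is also beyond the scatter. For the measured compounds named here, the three differ in more than one place, so no single step between them can be isolated; their values only show that compound 2 sits well apart at the weak end.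

Compound 4 `N/C(=N\NC(=S)N1CCSCC1)c1ccccn1` has not yet been measured. It differs from compound 2 by a single change: thiomorpholin-4-yl in place of morpholin-4-yl on a thiocarbonyl carbon. Going by the values given here, no measured pair shows this exact exchange, so its effect has to be judged without a direct precedent.

Given that only one ring atom is exchanged and the rest of the structure is kept, the step from compound 2 to compound 4 in this assay is expected to be small, most likely within the scatter, with a slight lean upward. Compound 4 is therefore estimated at 30% in this assay, within a range from 12% to 55%, which corresponds to an expected step of a number 10.7 percentage points higher from compound 2 to compound 4 (beyond the scatter).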

Compound 4, percent growth inhibition at one concentration: 80%
For compound 4 the middle estimate is 50 percentage points below the measured one, and the stated range ends below it.
By their numbers in this assay, from the lowest: compound 2; then compound 1; then compounds 4 and 3 (each within the scatter of the next).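

In this assay, for the compounds shown here, thiomorpholin-4-yl in place of morpholin-4-yl on a thiocarbonyl carbon gives a number 60.7 percentage points higher from compound 2 to compound 4 (beyond the scatter) and is the first change in this set that can be read on its own. The earlier compounds shown here differed in more than one place and could only place compound 2 at the weak end, whereas this pair shows that the ring on the thiocarbonyl carbon matters strongly: the exchange of ring oxygen for ring sulfur alone separates the two compounds, with the heavy-atom, donor and acceptor counts of the group unchanged. Nothing given here explains why this single atom exchange has so large an effect.

From the compounds shown here alone, what piperidin-1-yl, which carries a ring carbon where these two groups carry oxygen or sulfur, would give on the same thiocarbonyl carbon remains open, and that comparison would show whether the sulfur itself is needed or whether the oxygen is what holds compound 2 down. Also open, going by these compounds, is whether the same exchange would have a similar size on a core carrying a fluoro or methyl group on its pyridine ring, and whether it would hold at other concentrations.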